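The compounds below may be only part of what the source reports. "The series", "measured", "known", "first", "only" and "open" are said of these compounds alone.

Measured so far:
compound 1 `COc1ccc(/C=C2/CN(C)/C(=N/c3ccc(C(C)(C)C)cc3)S2)cc1` — 25900 nM
compound 2 `COc1ccc(/C=C2/CN(C)/C(=N/c3ccc(C)cc3)S2)cc1` — 11100 nM

Among the measured compounds shown here, in a functional assay on HCT-116 cells (Homo sapiens) for antiproliferative activity, read by MTT assay, with a stated time of 72 h (on this read-out higher numbers stand for weaker inhibition and lower numbers for stronger inhibition), compound 2 gives the lowest of the two numbers; its nearest neighbour is compound 1, and the only measured step, a 2.3-fold lower number from compound 1 to compound 2 (0.37 log units; beyond the scatter), is modest. Compound 3 `COc1ccc(/C=C2/CN(C)/C(=N/c3ccc(OC)cc3)S2)cc1` differs from compound 2 by methoxy in place of methyl on an aromatic carbon. For the measured compounds named here, no measured step covers that change, and the single step on the shared core does not speak to it directly, so no step beyond the scatter is expected in this assay. Compound 3 is therefore estimated at 9500 nM, between 3500 nM and 26000 nM, meaning an expected step of a 1.2-fold lower number from compound 2 to compound 3 (0.07 log units; within the scatter).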

Compound 3, half-maximal inhibitory concentration: 15900 nM
Beside the measured number, compound 3's estimate is 1.7-fold (0.22 log units) below it, and the stated range covers the measured number.
By their numbers in this assay, from the lowest: compounds 2, 3 and 1 (each within the scatter of the next, the first and the last beyond it).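

In this assay methoxy in place of methyl on this aromatic carbon, para to a large group, gives a 1.4-fold higher number from compound 2 to compound 3 (0.16 log units; within the scatter) and methoxy in place of tert-butyl gives a 1.6-fold lower number from compound 1 to compound 3 (0.21 log units; within the scatter) while the two groups it is compared with stand beyond the scatter of each other. The 4-methoxyphenyl compound therefore cannot be told apart from either neighbour, and adding a hydrogen-bond acceptor here brings no step beyond the scatter. No evidence bears on the reason for this result. The compounds shown leave open whether chlorine, an amine or a carboxylic acid at this position would give a step beyond the scatter.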